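The compounds below may be only part of what the source reports. "The series", "measured", "known", "first", "only" and "open" are said of these compounds alone.

Within the data shown here, in a functional assay on NCI-H23 cells (Homo sapiens) for antiproliferative activity, read by sulforhodamine B assay (a higher number here means a weaker inhibitor of growth, a lower number a stronger inhibitor of growth), compound 2 (`CC(C)CCOc1cccc(O)c1C(=O)/C=C/c1ccc(O)cc1`) gives 12100 nM, the only true number so far. Compound 1 (`CCCCCCOc1cccc(O)c1C(=O)/C=C/c1ccc(O)cc1`) gives > 30000 nM, which is a limit of the assay. Compound 3 (`O=C(/C=C/c1ccc(O)cc1)c1c(O)cccc1OCCC1CCCC1`) differs from compound 2 by cyclopentyl in place of isopropyl on a saturated chain carbon, two bonds along the chain from an oxygen on an aromatic ring, cyclopentyl in place of isopropyl. Among the measured compounds shown here, the one measured step at this place is an at least 2.4-fold lower number from compound 1 to compound 2 (0.39 log units; beyond the scatter), with isopropyl in place of butyl, and it is bounded on one side and involves no ring. It therefore guides direction only weakly. The expected step is a 1.5-fold higher number from compound 2 to compound 3 (0.17 log units; within the scatter), small and toward a higher number. For compound 3 the estimate is 18000 nM, with an expected range of 8000 nM to 30000 nM.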

Compound 3, concentration for 50% growth inhibition: 3370 nM
Compound 3: the middle estimate sits 5.3-fold (0.73 log units) above what was measured; the whole stated range lies above it.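

In this assay, this position now has a step measured between two true numbers, and cyclopentyl in place of isopropyl gives a 3.6-fold lower number from compound 2 to compound 3 (0.56 log units; beyond the scatter). Cyclopentyl in place of butyl gives an at least 8.9-fold lower number from compound 1 to compound 3 (0.94 log units; beyond the scatter), so among these three end groups the ring gives the strongest growth inhibition. That second step is bounded on one side, as compound 1 stands at a limit: the limit of > 30000 nM in this assay, at which 1 of the 3 values shown sits.

As far as these compounds go, whether a cyclohexyl or phenyl group at the chain end would go further remains open. So does the effect of an amine there, or of a shorter or longer chain carrying the cyclopentyl.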